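Adding a methyl to the side chain of compound 2

The source may report more compounds than this note shows. Statements on the series, on what has been measured and on what is new or still open speak of the compounds shown alone.

Compound 1 `COC(=O)c1nc(C)n(-c2ccc(C(F)(F)F)cc2)n1` sits at the limit of > 100000 nM in this assay, at which 1 of the 2 values shown sits. In a functional assay on NPC-TW01 cells (Homo sapiens) for inhibition, read by MTT assay, with a stated time of 72 h (on this read-out higher numbers stand for weaker inhibition of growth and lower numbers for stronger inhibition of growth), compound 1 therefore shows > 100000 nM, a limit rather than a number. Among the compounds with values here, compound 2 `COC(=O)c1nc(C)n(-c2ccc(F)cc2)n1`, which carries fluoro in place of trifluoromethyl on an aromatic carbon, gives 15200 nM in this assay; this is the only real number among the two values shown. The change brought an at least 6.5-fold lower number from compound 1 to compound 2 (0.81 log units; beyond the scatter). Compound 3 `CCc1nc(C(=O)OC)nn1-c1ccc(F)cc1` differs from compound 2 by methyl in place of hydrogen on a saturated chain carbon bound to an aromatic carbon. Within the data shown here, no measured step touches this place, so the only measured step, an at least 6.5-fold lower number from compound 1 to compound 2 (0.81 log units; beyond the scatter), cannot guide it. Compound 3 is therefore expected to stay within the scatter of compound 2, with a 1.0-fold lower number from compound 2 to compound 3 (0.01 log units; within the scatter). The estimate for compound 3 in this assay is 15000 nM, with a range from 6000 nM to 38000 nM.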

Compound 3, concentration for 50% growth inhibition: 15800 nM
Compound 3: the middle estimate sits 1.1-fold (0.02 log units) below what was measured; the range from low to high includes it.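

The step read in this assay is a 1.0-fold higher number from compound 2 to compound 3 (0.02 log units; within the scatter) and so shows that methyl in place of hydrogen at this place, a saturated chain carbon bound to an aromatic carbon, leaves growth inhibition unchanged within the scatter. Within the data shown here, the earlier step concerned only fluoro in place of trifluoromethyl on an aromatic carbon, so this is the first reading of the side chain, and here methyl to ethyl is tolerated. Nothing measured here offers a reason for this result.

Going by these compounds, whether this tolerance extends to a longer chain such as propyl, or to a chain ending in an amine or a carboxylic acid, remains open. On these data alone, it is also open whether a small ring such as cyclopropyl would behave like ethyl at this place.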